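Trimethoxyphenyl pyrimidines: swapping the second aryl group

This account rests on a few compounds, and the source may have more. Where it says the series, first, only, none or still open, it means among the compounds named here.

Measured so far:
compound 1 `COc1ccc(-c2cncnc2-c2cc(OC)c(OC)c(OC)c2)cc1` gives 2850 nM
compound 2 `COc1ccc(-c2cncnc2-c2cc(OC)c(OC)c(OC)c2)cc1Cl` gives 1330 nM
compound 3 `COc1cc(-c2ncncc2-c2ccc(C(N)=O)cc2)cc(OC)c1OC` sits at a limit, > 100000 nM

In a functional assay on SiHa cells (Homo sapiens) for antiproliferative activity, read by CCK-8 assay, with a stated time of 72 h (on this read-out lower numbers stand for stronger inhibition and higher numbers for weaker inhibition), compound 2 holds the lowest of the two numbers; compound 1 is nearest, separated by a 2.1-fold lower number from compound 1 to compound 2 (0.33 log units; beyond the scatter). The value of compound 3 is a limit of the assay, not a number (the limit of > 100000 nM in this assay, at which 1 of the 3 values shown sits).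

Compound 4 `COc1cc(-c2ncncc2-c2ccc(Br)cc2)cc(OC)c1OC` differs from compound 2 by 4-bromophenyl in place of 3-chloro-4-methoxyphenyl on an aromatic carbon. Going by the values given here, two measured steps bear on this: an at least 75-fold higher number from compound 2 to compound 3 (1.87 log units; beyond the scatter), where the same group leaves, and an at least 35-fold higher number from compound 1 to compound 3 (1.54 log units; beyond the scatter), where methoxy is lost; both are large. Compound 4 also loses the methoxy but takes in a bromo rather than carbamoyl, so a smaller loss is expected. For compound 4 the expected step is a 6.0-fold higher number from compound 2 to compound 4 (0.78 log units; beyond the scatter). Compound 4 is estimated at 8000 nM, ranging from 2000 nM to 40000 nM.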

Compound 4, half-maximal inhibitory concentration: 2960 nM
Beside the measured number, compound 4's estimate is 2.7-fold (0.43 log units) above it, and the stated range covers the measured number.
By their numbers in this assay, from the lowest: compound 2; then compounds 1 and 4 (each within the scatter of the next). At a limit, above all of these: compound 3.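

In this assay, this place on the shared core accepts bromo in place of methoxy, with a 1.0-fold higher number from compound 1 to compound 4 (0.02 log units; within the scatter), so the methoxy is not needed here for activity at this level. Carbamoyl stands apart, with an at least 33-fold lower number from compound 3 to compound 4 (1.52 log units; beyond the scatter), while 3-chloro-4-methoxyphenyl keeps a modest edge over 4-bromophenyl, with a 2.2-fold higher number from compound 2 to compound 4 (0.35 log units; beyond the scatter). The value of compound 3 is a limit of the assay, not a number: the limit of > 100000 nM in this assay, at which 1 of the 4 values shown sits.

From the compounds shown here alone, whether an amine or a carboxylic acid in the same place falls as far as carbamoyl remains open. So does whether fluoro or methyl matches bromo.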